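Replacing methoxy with dimethylamino in a small compound series

The source may hold more compounds than are shown below. What is called first, only, known or untested is meant among the compounds shown, and "the series" means these compounds.

Compound 1 (`Fc1ccc(-c2ccc(-c3ccc(-c4nc5ccccc5[nH]4)cc3)cc2)cc1`) – 100000 nM
Compound 2 (`COc1ccc(-c2ccc(-c3ccc(-c4nc5ccccc5[nH]4)cc3)cc2)cc1`) – 45200 nM

Within the data shown here, in a functional assay on COLO 205 cells (Homo sapiens) for inhibition, read by sulforhodamine B assay (a lower number here means a stronger inhibitor of growth, a higher number a weaker inhibitor of growth), compound 2 gives 45200 nM as the lower of the two numbers measured so far, while compound 1 gives 100000 nM as the higher. The next compound, compound 3 (`CN(C)c1ccc(-c2ccc(-c3ccc(-c4nc5ccccc5[nH]4)cc3)cc2)cc1`), has not yet been measured. It carries dimethylamino in place of methoxy on an aromatic carbon, para to a large group: dimethylamino in place of methoxy on an aromatic carbon and the shared core stays unchanged.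

Among the measured compounds shown here, only one measured step bears on this change. Methoxy in place of fluoro at the same carbon gave a 2.2-fold lower number from compound 1 to compound 2 (0.34 log units; beyond the scatter) and this was modest. For the measured compounds named here, a single step involving a different pair of groups is a weak guide, and no measurement yet shows how dimethylamino behaves here. A modest move in the same direction therefore seems the most reasonable expectation, with real doubt about its size. The estimated step is a 2.3-fold lower number from compound 2 to compound 3 (0.35 log units; beyond the scatter) in this assay.

For compound 3 the expected value is 20000 nM within an estimated range of 6000 nM to 60000 nM in this assay as read so far.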

Compound 3, concentration for 50% growth inhibition: 100000 nM
Beside the measured number, compound 3's estimate is 5.0-fold (0.70 log units) below it; measured number above the stated range.
By their numbers in this assay, from the lowest: compound 2; then compounds 1 and 3 (each within the scatter of the next).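

In this assay, putting dimethylamino in place of methoxy on this aromatic carbon, para to a large group, gave a 2.2-fold higher number from compound 2 to compound 3 (0.34 log units; beyond the scatter), so the modest gain seen with methoxy did not extend to dimethylamino. Dimethylamino in place of fluoro gave no change at the digits printed from compound 1 to compound 3 (within the scatter), which leaves methoxy as the only one of the three groups whose number stands apart at this carbon, with compound 2 lowest of the series. Nothing shown here explains why methoxy and dimethylamino differ at this carbon.

With only three groups at a single carbon, the compounds shown leave open whether the lower number of compound 2 is specific to methoxy or would also appear with a longer chain such as ethoxy, or with a hydroxyl or a primary amine at the same carbon. They also leave open whether a carboxylic acid there would move the number in either direction, and whether the same order of groups would hold if the shared core were changed elsewhere.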